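The source may hold more compounds than are shown below. What is called first, only, known or untested is meant among the compounds shown, and "the series" means these compounds.

- Compound 1 `C/C(=N\Nc1nc(C)cs1)c1ccc(Cl)c(Cl)c1`: 33700 nM
- Compound 2 `C/C(=N\Nc1nc(-c2ccc(F)cc2)cs1)c1ccc(Cl)c(Cl)c1`: > 50000 nM (a limit of the assay)
- Compound 3 `C/C(=N\Nc1nc(-c2ccc(Cl)cc2)cs1)c1ccc(Cl)c(Cl)c1`: not yet measured

In an ADME assay on J774 cells (Mus musculus) for cytotoxicity, read by resazurin assay, with a stated time of 72 h (a higher number here means that more compound is tolerated, a lower number that less compound is tolerated), compound 1 gives 33700 nM. Compound 2 gives > 50000 nM, which is a limit of the assay and not a number. Its place on the scale is therefore known only as the limit of > 50000 nM in this assay, at which 1 of the 2 values shown sits.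

Compound 3 differs from compound 2 at one place: chloro in place of fluoro on an aromatic carbon. This is chloro in place of fluoro on an aromatic carbon, para to a large group, so 4-fluorophenyl becomes 4-chlorophenyl.

Within the data shown here, only one measured step lies close to this change: an at least 1.4-fold higher number from compound 1 to compound 2 (0.17 log units; that floor lies within the scatter). That step put 4-fluorophenyl in place of methyl, so it is a different exchange, and its floor stays within the scatter. Among the measured compounds shown here, no measured step swaps one of these two atoms for the other. No step beyond the scatter is therefore expected in this assay, in either direction, and compound 3 may also be reported only as a limit.

For compound 3, the expected value is 45000 nM, with an estimated range from 20000 nM to 80000 nM. The expected change is an at least 1.1-fold lower number from compound 2 to compound 3 (0.04 log units; that floor lies within the scatter).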

Compound 3, half-maximal cytotoxic concentration: > 50000 nM
Compound 3 gave a limit, no number; the forecaster's own chance of this, stated with the estimate: 50%; at least 1.1-fold (0.04 log units) between middle value and limit.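

In this assay compound 3 gives > 50000 nM, which is a limit of the assay and not a number. The change from 4-fluorophenyl to 4-chlorophenyl therefore cannot be read as a step, and the two compounds can only be said to share the same ceiling: the limit of > 50000 nM in this assay, at which 2 of the 3 values shown sit.

What this result adds is a second halogen at this place on the phenyl ring, and the comparison with the methyl compound still gives only an at least 1.4-fold higher number from compound 1 to compound 3 (0.17 log units; that floor lies within the scatter), so cells show no loss of tolerance with chloro here, though this floor does not separate the two compounds beyond normal scatter.

Where compound 2 and compound 3 truly lie on the scale stays open, and so does any real difference between fluoro and chloro at this place. Also open, on these data alone, is whether an amine or a carboxylic acid on this phenyl ring, in place of the halogen, would leave the reading at this limit or give a number that can be compared.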